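A few compounds are considered here, and "the series" means these few. Any claim that something is new, unique, unknown or untested is made for them only; others in the source may bear on it.

Of the compounds shown here, three of one series have been measured in a functional assay on Venous blood for antagonist activity at C-X-C chemokine receptor type 3 (Homo sapiens), read by flow cytometry, with a stated time of 30 min, in the presence of a further agent that is not named here; on this read-out lower numbers stand for stronger inhibition and higher numbers for weaker inhibition. Compound 1 `C[C@@H]1CN(c2sc(C(F)(F)F)nc2-c2nc3cc(OCCO)ccc3[nH]2)CCN1C(=O)Cn1cnc2cccnc21` gives 99.1 nM, compound 2 `C[C@@H]1CN(c2sc(C(F)(F)F)nc2-c2nc3ccccc3[nH]2)CCN1C(=O)Cn1cnc2c1CCN(C)C2` gives 135 nM, and compound 3 `Cc1nc(C)n(CC(=O)N2CCN(c3sc(C(F)(F)F)nc3-c3nc4ccc(S(C)(=O)=O)cc4[nH]3)C[C@H]2C)n1` gives 959 nM. Compound 2 holds the second highest of the three numbers: its value and that of compound 1 lie within the usual scatter of each other, so no order can be read between them, while the gap to compound 3 lies beyond the scatter and compound 3 is the weaker of that pair.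

Compound 4 `COC1CCN(CC(=O)N2CCN(c3sc(C(F)(F)F)nc3-c3nc4ccccc4[nH]3)C[C@H]2C)C1` differs from compound 2 in one place: a group of 7 heavy atoms (5 carbon, 1 nitrogen, 1 oxygen; one five-membered non-aromatic ring with 1 hetero atom) in place of a group of 10 heavy atoms (7 carbon, 3 nitrogen; one five-membered aromatic ring with 2 hetero atoms, one six-membered non-aromatic ring with 1 hetero atom), on a saturated chain carbon bound to a carbonyl carbon. Within the data shown here, no measured pair in this set shows such an exchange, so its effect can only be guessed. Among the measured compounds shown here, since the data give no direct precedent, the expectation is for a modest loss in this assay , with the step from compound 2 to compound 4 estimated at a 2.4-fold higher number from compound 2 to compound 4 (0.37 log units; beyond the scatter). Compound 4 is therefore expected to give about 320 nM, likely between 110 nM and 950 nM.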

Compound 4, half-maximal inhibitory concentration: 3380 nM
For compound 4 the middle estimate is 11-fold (1.02 log units) below the measured one, and the stated range ends below it.
By their numbers in this assay, from the lowest: compounds 1 and 2 (each within the scatter of the next); then compound 3; then compound 4.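

At the saturated chain carbon bound to a carbonyl carbon, replacing the group with one five-membered aromatic ring and one six-membered non-aromatic ring by 3-methoxypyrrolidin-1-yl gives a large loss in this assay, with a 25-fold higher number from compound 2 to compound 4 (1.40 log units; beyond the scatter). Among these compounds, this is the first one-place step, and it shows that the outcome in this assay depends strongly on the group held at this position, which the earlier compounds, differing in several places, could not show. Nothing available here accounts for the size of this loss.

The compounds shown leave open whether the loss follows from the methoxy group, the pyrrolidine ring or the absence of the fused ring system. Plain pyrrolidin-1-yl and imidazol-1-yl at this position would help to separate these possibilities.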